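A few compounds are considered here, and "the series" means these few. Any claim that something is new, unique, unknown or untested is made for them only; others in the source may bear on it.

Measured so far in a functional assay on HeLa cells (Homo sapiens) for antiproliferative activity, read by MTT assay, with a stated time of 72 h; a higher number here means a weaker inhibitor, a lower number a stronger inhibitor:
Compound 1 `COc1cccc(N2C(=O)COc3ccc(-c4cnc(Cl)c(NS(=O)(=O)c5ccc(F)cc5)c4)cc32)c1` gives > 40000 nM, which is a limit of the assay and not a number.
Compound 2 `COc1ccc(N2C(=O)COc3ccc(-c4cnc(OC)c(NS(=O)(=O)c5ccc(F)cc5)c4)cc32)cc1` gives 1220 nM.
Compound 3 `O=C1COc2ccc(-c3cnc4ccccc4c3)cc2N1` gives > 40000 nM, which is likewise a limit of the assay and not a number.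

Compound 2 is the only one of the three with a number in this assay; the two other values sit at the limit of > 40000 nM in this assay, at which 2 of the 3 values shown sit. Among the compounds with values here, no step between measured compounds that differ in one place is available, so the move to compound 4 `COc1ncc(-c2ccc3c(c2)N(c2ccc(F)cc2)C(=O)CO3)cc1NS(=O)(=O)c1ccc(F)cc1` has no direct precedent. Compound 4 differs from compound 2 by fluoro in place of methoxy on an aromatic carbon. In this assay the expected step is no larger than the scatter, leaning if anywhere toward weaker inhibition. Compound 4 is accordingly estimated at 1600 nM, within 500 nM to 5000 nM. That estimate means an expected step of a 1.3-fold higher number from compound 2 to compound 4 (0.12 log units; within the scatter).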

Compound 4, half-maximal inhibitory concentration: 10500 nM
For compound 4 the middle estimate is 6.6-fold (0.82 log units) below the measured one, outside the stated range (above it).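

In this assay, within the data shown here, the change from 4-methoxyphenyl to 4-fluorophenyl gives the only readable step: an 8.6-fold higher number from compound 2 to compound 4 (0.93 log units; beyond the scatter). Among these compounds, this position, para to a large group, is therefore not indifferent to its substituent, which the earlier compounds could not show, as no two of them differed in one place. Compound 4 still carries a number and not a limit of the assay: the limit of > 40000 nM in this assay, at which 2 of the 4 values shown sit.

As far as these compounds go, whether the shift tracks the loss of methoxy or the arrival of fluoro remains open. An amine, a hydroxyl or a plain hydrogen at this position would help separate the two readings.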